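Extending the Amine Chain of Compound 2 by One Carbon

The compounds below may be only part of what the source reports. "The series", "measured", "known", "first", "only" and "open" are said of these compounds alone.

In a functional assay on HT-29 cells (Homo sapiens) for antiproliferative activity, read by MTT assay, with a stated time of 72 h (on this read-out lower numbers stand for stronger inhibition and higher numbers for weaker inhibition), the three measured compounds gave these numbers:

Compound 1, `CN(C)CCn1cnnc1-c1cc(Oc2ccc(NC(=O)Nc3ccc(Cl)c(C(F)(F)F)c3)cc2F)ccn1`: 880 nM
Compound 2, `CCN(CC)CCn1cnnc1-c1cc(Oc2ccc(NC(=O)Nc3ccc(Cl)c(C(F)(F)F)c3)cc2F)ccn1`: 900 nM
Compound 3, `CCN(CC)CCn1cnnc1-c1cc(Oc2ccc(NC(=O)Nc3ccc(F)c(Cl)c3)cc2F)ccn1`: 500 nM

Compound 2 holds the highest of the three numbers, yet neither step that separates it from the others rises beyond the scatter: a 1.0-fold higher number from compound 1 to compound 2 (0.01 log units; within the scatter) and a 1.8-fold lower number from compound 2 to compound 3 (0.26 log units; within the scatter). On these numbers the three compounds cannot be told apart with confidence.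

Compound 4, `CN(C)CCCn1cnnc1-c1cc(Oc2ccc(NC(=O)Nc3ccc(Cl)c(C(F)(F)F)c3)cc2F)ccn1`, is not yet measured. It differs from compound 2 in one place: (dimethylamino)methyl in place of diethylamino on a saturated chain carbon, two bonds along the chain from an aromatic nitrogen. Within the data shown here, of the two measured steps, only the one from compound 1 to compound 2 touches the same place, where the amine substituents changed while the chain kept its length, and that step was flat. The step from compound 2 to compound 3 concerns the aryl group on the urea and does not bear on this change. Among the measured compounds shown here, there is no measured example of a longer chain at this position, so nothing in the data points to a shift in either direction.

Compound 4 is therefore expected to stay close to compound 2 in this assay, with an estimated step of a 1.1-fold lower number from compound 2 to compound 4 (0.02 log units; within the scatter). The estimate for compound 4 is 850 nM, with a range from 400 nM to 2000 nM.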

Compound 4, half-maximal inhibitory concentration: 1400 nM
Estimate against measurement, compound 4: 1.6-fold (0.22 log units) below; the range from low to high includes it.
By their numbers in this assay, from the lowest: compounds 3, 1, 2 and 4 (each within the scatter of the next, the first and the last beyond it).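

In this assay, among these compounds, the new compound gives the first reading of chain length at this position, on a saturated chain carbon, two bonds along the chain from an aromatic nitrogen: with the dimethylamino group held constant, 3-(dimethylamino)propyl in place of 2-(dimethylamino)ethyl gives a 1.6-fold higher number from compound 1 to compound 4 (0.20 log units; within the scatter) and so stays within the scatter. The change from 2-(diethylamino)ethyl to 3-(dimethylamino)propyl, which alters the amine substituents and the chain together, gives a 1.6-fold higher number from compound 2 to compound 4 (0.19 log units; within the scatter) and also stays within the scatter, so among compounds 1, 2 and 4 neither kind of change at this position produces a step beyond the scatter. No measurement is available that would explain these small steps.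

On these data alone, whether a 3-(diethylamino)propyl chain, a longer 4-(dimethylamino)butyl chain or a ring amine such as morpholine or piperidine on the chain would also stay within the scatter remains open. As far as these compounds go, it is equally open how the 3-(dimethylamino)propyl chain would read in this assay alongside the 3-chloro-4-fluorophenyl group of compound 3 in place of the 4-chloro-3-(trifluoromethyl)phenyl group.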